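The compounds below may be only part of what the source reports. "The series", "measured", "known", "first", "only" and "open" are said of these compounds alone.

Measured so far in an assay on CHO cells for displacement of a labelled ligand from adenosine receptor A3 (Homo sapiens), with a stated time of 60 min; a higher number here means a weaker inhibitor, a lower number a stronger inhibitor:
- compound 1 `O[C@@H]1[C@H](O)[C@@H]2C[C@@H]2[C@H]1n1cnc2c(NC3CCC3)nc(Cl)nc21`: 5.9 nM
- compound 2 `O[C@@H]1[C@H](O)[C@@H]2C[C@@H]2[C@H]1n1cnc2c(NCCCF)nc(Cl)nc21`: 32.4 nM

Compound 2 stands at the higher of these two numbers, the weaker of the pair. Within the data shown here, the only step measured so far is a 5.5-fold higher number from compound 1 to compound 2 (0.74 log units; beyond the scatter), where a ring on the amine nitrogen gave way to a chain. Compound 3 `O[C@@H]1[C@H](O)[C@@H]2C[C@@H]2[C@H]1n1cnc2c(NCc3ccccc3F)nc(Cl)nc21` now differs from compound 2 by 2-fluorophenyl in place of 2-fluoroethyl on a saturated chain carbon bound to a nitrogen on an aromatic ring. That earlier step bears on this change only loosely, since the ring that enters here is aromatic, but restoring a ring on this amine is expected to bring the number back down by a 3.2-fold lower number from compound 2 to compound 3 (0.51 log units; beyond the scatter). Compound 3 is therefore expected to give about 10 nM, within a range from 3 nM to 40 nM.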

Compound 3, inhibition constant: 41.5 nM
Beside the measured number, compound 3's estimate is 4.2-fold (0.62 log units) below it, and the stated range ends below it.
By their numbers in this assay, from the lowest: compound 1; then compounds 2 and 3 (each within the scatter of the next).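

Putting 2-fluorophenyl in place of 2-fluoroethyl on a saturated chain carbon bound to a nitrogen on an aromatic ring gives a 1.3-fold higher number from compound 2 to compound 3 (0.11 log units; within the scatter) in this assay and so leaves the number within the scatter, whether this position carries a fluorinated chain or an aromatic ring. A ring on this side chain is therefore not enough to match the cyclobutyl group, as a 7.0-fold higher number from compound 1 to compound 3 (0.85 log units; beyond the scatter) shows for 2-fluorobenzyl in place of cyclobutyl. No measured evidence here accounts for these numbers.

Still open, as far as these compounds go, is whether a plain benzyl or a cyclopentyl group on this nitrogen would fall nearer compound 1 or nearer compound 2.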